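Swapping fluoro for methoxy on an amide-linked phenyl ring

This account rests on a few compounds, and the source may have more. Where it says the series, first, only, none or still open, it means among the compounds named here.

Compound 1 `COc1cc(C(=O)Nc2ccc(C(=O)/C=C/c3nc(C)c(C)nc3C)cc2)cc(OC)c1OC` gives 4860 nM in a functional assay on HepG2 cells (Homo sapiens) for antiproliferative activity, read by CCK-8 assay, with a stated time of 72 h; on this read-out lower numbers stand for stronger inhibition and higher numbers for weaker inhibition; compound 2 `COc1ccc(C(=O)Nc2ccc(C(=O)/C=C/c3nc(C)c(C)nc3C)cc2)cc1OC` gives 2560 nM in this assay; compound 3 `Cc1nc(C)c(/C=C/C(=O)c2ccc(NC(=O)c3ccc(F)cc3)cc2)nc1C` gives 2250 nM in this assay.

Compound 3 carries the lowest of the three numbers. Its nearest neighbour is compound 2, whose step a 1.1-fold lower number from compound 2 to compound 3 (0.06 log units; within the scatter) stays within the scatter, while the gap to compound 1 lies beyond it. The earlier step of a 1.9-fold lower number from compound 1 to compound 2 (0.28 log units; within the scatter) also stays within the scatter.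

Compound 4 `COc1ccc(C(=O)Nc2ccc(C(=O)/C=C/c3nc(C)c(C)nc3C)cc2)cc1` differs from compound 3 by one change: methoxy in place of fluoro on an aromatic carbon. Both measured steps touch the same phenyl ring that hangs from the amide carbonyl, and both were small: removing one methoxy from compound 1 to compound 2, and replacing the remaining dimethoxy pattern by a single fluoro from compound 2 to compound 3. Compound 4 sits between those two patterns. A change no larger than the scatter is therefore expected, in no firm direction, as a 1.2-fold higher number from compound 3 to compound 4 (0.06 log units; within the scatter). Compound 4 is estimated at 2600 nM, within 1300 nM to 5200 nM.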

Compound 4, half-maximal inhibitory concentration: 1190 nM
For compound 4 the middle estimate is 2.2-fold (0.34 log units) above the measured one; measured number outside the range, below it.
By their numbers in this assay, from the lowest: compounds 4, 3, 2 and 1 (each within the scatter of the next, the first and the last beyond it).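

Within the data shown here, with compound 4, a step on the ring attached to the amide carbonyl passes the scatter for the first time in this assay: removing one methoxy from the dimethoxy pattern gives a 2.2-fold lower number from compound 2 to compound 4 (0.33 log units; beyond the scatter) and counts as a modest change. At the position para to a large group, the exchange of fluoro for methoxy gives a 1.9-fold lower number from compound 3 to compound 4 (0.28 log units; within the scatter) and stays within the scatter, so these two compounds cannot be told apart, even though the groups differ in name and size.

An amine or a nitrile at this same position could show whether this ring allows larger changes in the number than those seen so far. No available measurement gives a reason for either step.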